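The source may report more compounds than this note shows. Statements on the series, on what has been measured and on what is new or still open speak of the compounds shown alone.

Measured so far:
compound 1 `CC(Cl)CC(=O)NC1=C(C#N)C(c2ccc(Cl)cc2Cl)C2=C(CCCC2=O)N1c1ccc(S(N)(=O)=O)cc1` — 50%
compound 2 `N#CC1=C(NC(=O)c2ccc([N+](=O)[O-])cc2)N(c2ccc(S(N)(=O)=O)cc2)C2=C(C(=O)CCC2)C1c1ccc(Cl)cc1Cl` — 40%
compound 3 `NC1=C(C(=O)O)C(c2ccc(Cl)cc2Cl)C2=C(CCCC2=O)N1c1ccc(S(N)(=O)=O)cc1` — 0%

In a functional assay on Ehrlich cells (Mus musculus) for cytotoxicity, read by trypan blue exclusion, with a stated time of 2 h, tested at 25 ug/mL (a lower number here means a weaker effect, a higher number a stronger effect of the compound at the concentration tested), compound 1 stands highest of the three numbers; the nearest is compound 2, whose value is a number 10 percentage points lower from compound 1 to compound 2 (within the scatter), so within the scatter; compound 3, with 0%, is the furthest and lies beyond it. Compound 4 `CN(C)c1ccc(/C=N/C2=C(C#N)C(c3ccc(Cl)cc3Cl)C3=C(CCCC3=O)N2c2ccc(S(N)(=O)=O)cc2)cc1` remains to be measured. It differs from compound 1 as follows: a group of 11 heavy atoms (9 carbon, 2 nitrogen; one six-membered aromatic ring of carbon only) in place of a group of 7 heavy atoms (4 carbon, 1 nitrogen, 1 oxygen, 1 chlorine; no ring), on a double-bonded ring carbon. For the measured compounds named here, the only measured step touching the same region is a number 10 percentage points lower from compound 1 to compound 2 (within the scatter), a swap on the carbonyl carbon that stayed within the scatter. Going by the values given here, no measured step removes the ((2-chloropropyl)carbonyl)amino group itself or introduces a group like the entering one, so any expectation is loosely founded. Compound 4 is therefore expected to give about 40%, in a range of 15% to 65%, which amounts to an expected step of a number 10 percentage points lower from compound 1 to compound 4 (within the scatter).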

Compound 4, a percentage reported as activity, at one concentration (the size of the read-out at that concentration, not a potency): 30%
Beside the measured number, compound 4's estimate is 10 percentage points above it, within the range that was stated.
By their numbers in this assay, from the lowest: compound 3; then compounds 4, 2 and 1 (each within the scatter of the next, the first and the last beyond it).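

In this assay, for the compounds shown here, replacing the ((2-chloropropyl)carbonyl)amino group at this position gives a number 20 percentage points lower from compound 1 to compound 4 (beyond the scatter), the first step to exceed the scatter, although compound 4 still retains 30%. The two groups bearing a six-membered aromatic ring give a number 10 percentage points lower from compound 2 to compound 4 (within the scatter), so compound 2 and compound 4 cannot be ordered. Nothing available accounts for either step. As far as these compounds go, a free amine on this ring carbon with the cyano group retained remains open. So does a longer chain on the carbonyl carbon.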